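Piperazine in Place of Fluorophenyl on a Shared Core

A few compounds are considered here, and "the series" means these few. Any claim that something is new, unique, unknown or untested is made for them only; others in the source may bear on it.

The study measures cytotoxicity in an ADME assay on THP-1 cells (Homo sapiens) for cytotoxicity, read by MTT assay, with a stated time of 72 h; a higher number here means that more compound is needed for the effect, a lower number that less compound is needed. Of the compounds shown here, three that share one core have been measured. Compound 1 (`CN(C)c1ccc(-c2ccc3[nH]c(=O)nc(-c4ccccc4)c3c2)cn1`) reaches only a limit of the assay in this assay, at > 50000 nM. Compound 3 (`N#Cc1ccc(-c2cccc3[nH]c(=O)nc(-c4ccccc4)c23)cc1`) likewise gives only a limit, at > 50000 nM. Within the data shown here, compound 2 (`O=c1nc(-c2ccccc2)c2cc(-c3ccccc3F)ccc2[nH]1`) is the single compound with a number: in this assay compound 2 gives 50000 nM, which sets it at the same concentration as the limit of > 50000 nM in this assay, at which 2 of the 3 values shown sit, so the three compounds cannot be ordered against one another. Among the measured compounds shown here, no step between measured compounds that differ in one place is available.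

Compound 4 (`O=c1nc(-c2ccccc2)c2cc(N3CCNCC3)ccc2[nH]1`) remains to be measured. It differs from compound 2 in a single place: piperazin-1-yl in place of 2-fluorophenyl on an aromatic carbon. For the measured compounds named here, with no measured step to show what this exchange does, the change in this assay is expected to be none beyond the scatter, in neither direction. The step this means, no change at the digits printed from compound 2 to compound 4 (within the scatter), is expected to stay within that scatter. Compound 4 is accordingly estimated at 50000 nM, in a range from 25000 nM to 100000 nM, with a real chance that the assay reports only a limit rather than a number.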

Compound 4, half-maximal effective concentration: > 25000 nM
Compound 4: no number, only a limit; the forecaster's own chance of this, stated with the estimate: 60%; the middle value lies beyond the limit too.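

In this assay compound 4 gives only a limit of the assay, > 25000 nM. Among these compounds, no step from compound 2 to compound 4 can therefore be read. The compounds shown leave open what number compound 4 would give, and whether piperazin-1-yl in place of 2-fluorophenyl changes the result in this assay at all.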